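This account rests on a few compounds, and the source may have more. Where it says the series, first, only, none or still open, it means among the compounds named here.

Measured compounds in an ADME assay on BHK-21 cells (Mesocricetus auratus) for cytotoxicity, read by MTT assay, with a stated time of 96 h; on this read-out higher numbers stand for lower toxicity in this test and lower numbers for higher toxicity in this test:
- compound 1 `O=[N+]([O-])c1cccc(/N=N/N2CCCC2)c1`, giving 42000 nM
- compound 2 `O=[N+]([O-])c1cccc(/N=N/Nc2cccc([N+](=O)[O-])c2)c1`, giving a result recorded only as a limit of the assay, > 100000 nM
- compound 3 `FC(F)(F)c1cccc(/N=N/c2ccc(NC[C@@H]3CCCN4CCCC[C@H]34)c3c2CCCC3)c1`, giving 14000 nM

Compound 3 carries the lowest of the two numbers shown in this assay. Its nearest neighbour is compound 1, whose value is higher than that of compound 3, and the gap between these two lies beyond the scatter. The remaining entry belongs to compound 2 and is a limit rather than a number; the assay reports for compound 2 only (the limit of > 100000 nM in this assay, at which 1 of the 3 values shown sits).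

Compound 4 `c1ccc(/N=N/c2ccc(NC[C@@H]3CCCN4CCCC[C@H]34)c3c2CCCC3)cc1` has not yet been measured in this assay. It differs from compound 3 in one place: hydrogen in place of trifluoromethyl on an aromatic carbon. Going by the values given here, no step between two measured compounds involves this kind of change, so there is no measured precedent for its size. The expectation is that compound 4 will sit close to compound 3, with a modest step from compound 3 to compound 4 estimated as a 1.4-fold higher number from compound 3 to compound 4 (0.15 log units; within the scatter), most likely within or only slightly beyond the scatter and tending toward a higher number. On that basis compound 4 is expected to give about 20000 nM in this assay, in a range from 8000 nM to 50000 nM.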

Compound 4, half-maximal cytotoxic concentration: > 100000 nM
Compound 4 ended at the assay's limit; the forecaster's own chance of this, stated with the estimate: 5%; at least 5.0-fold (0.69 log units) between middle value and limit.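

In this assay, going by these compounds alone, hydrogen in place of trifluoromethyl on an aromatic carbon gives an at least 7.1-fold higher number from compound 3 to compound 4 (0.85 log units; beyond the scatter), the first step that can be read between two compounds differing in one place. It shows that the read-out responds to this single place while the rest of the structure stays the same. Compound 4 is recorded only as a limit, so the step gives a minimum and not a full size: the limit of > 100000 nM in this assay, at which 2 of the 4 values shown sit.

The compounds shown leave open whether this shift is specific to trifluoromethyl, or whether a methyl, a chlorine or an amine on the same aromatic carbon would give a number like that of compound 3. They also leave open whether the same exchange would move the read-out by a similar amount on another core.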